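The compounds below may be only part of what the source reports. "The series", "measured", "known", "first", "only" and "open" are said of these compounds alone.

Compound 1 `CN1CCN(CCCCOc2c(OCc3ccco3)cc(O)c3c(=O)cc(-c4ccccc4)oc23)CC1` gives 3530 nM in a functional assay on B16 cells (Mus musculus) for cytotoxicity, read by MTT assay, with a stated time of 72 h; a higher number here means a weaker inhibitor, a lower number a stronger inhibitor; compound 2 `CN1CCN(CCCCOc2c(OCc3cccs3)cc(O)c3c(=O)cc(-c4ccccc4)oc23)CC1` gives 2120 nM in this assay.

Compound 2 stands at one end of these two numbers, but a 1.7-fold lower number from compound 1 to compound 2 (0.22 log units; within the scatter) lies within the scatter, so the two compounds cannot be told apart. Compound 3 `CN1CCN(CCCCOc2c(OCc3nc4ccccc4s3)cc(O)c3c(=O)cc(-c4ccccc4)oc23)CC1` differs from compound 2 by 1,3-benzothiazol-2-yl in place of thiophen-2-yl on a saturated chain carbon bound to an oxygen on an aromatic ring. Among the compounds with values here, the only measured step bearing on this change is a 1.7-fold lower number from compound 1 to compound 2 (0.22 log units; within the scatter), an exchange of one ring for another on the same carbon, and it stayed within the scatter. Compound 3 is therefore expected to show no step beyond the scatter, with a 1.1-fold lower number from compound 2 to compound 3 (0.03 log units; within the scatter). The estimate for compound 3 in this assay is 2000 nM, in the range 700 nM to 6000 nM.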

Compound 3, half-maximal inhibitory concentration: 2780 nM
Compound 3: middle estimate off by 1.4-fold (0.14 log units), on the low side; low and high end bracket the measured number.
By their numbers in this assay, from the lowest: compounds 2, 3 and 1 (each within the scatter of the next).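

In this assay, the step of a 1.3-fold higher number from compound 2 to compound 3 (0.12 log units; within the scatter) and the step of a 1.3-fold lower number from compound 1 to compound 3 (0.10 log units; within the scatter) both stay within the scatter, so adding a six-membered aromatic ring to the group on this carbon gives no readable change. The furan-2-yl, thiophen-2-yl and 1,3-benzothiazol-2-yl compounds therefore cannot be told apart at this position. No available evidence accounts for this result. Going by these compounds, all three groups are aromatic rings, so it remains open whether a cyclohexyl ring, a dimethylamino group or a carboxylic acid on this carbon would move the number beyond the scatter.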